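Para-substituent swap on the thiosemicarbazone phenyl ring

The source may hold more compounds than are shown below. What is called first, only, known or untested is meant among the compounds shown, and "the series" means these compounds.

Measured compounds:
Compound 1, `C=CCNC(=S)N/N=C\c1ccnc2ccccc12`: 1230 nM
Compound 2, `O=[N+]([O-])c1ccc(NC(=S)N/N=C\c2ccnc3ccccc23)cc1`: 1330 nM
Compound 3, `S=C(N/N=C\c1ccnc2ccccc12)Nc1ccc(Br)cc1`: 1480 nM

All three share a thiosemicarbazone core and were tested in a functional assay on T47D cells (Homo sapiens) for cytotoxicity, read by MTT assay, with a stated time of 48 h; on this read-out higher numbers stand for weaker inhibition and lower numbers for stronger inhibition. Compound 3 gives 1480 nM in this assay, and its neighbours are close: the step of a 1.1-fold higher number from compound 2 to compound 3 (0.05 log units; within the scatter) and the step of a 1.2-fold higher number from compound 1 to compound 3 (0.08 log units; within the scatter) both lie within the scatter, so the three numbers cannot be told apart.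

Compound 4, `Cc1ccc(NC(=S)N/N=C\c2ccnc3ccccc23)cc1`, has not yet been measured in this assay. It differs from compound 3 only at the para position of the phenyl ring: methyl in place of bromo on an aromatic carbon. Going by the values given here, the most closely related measured step is the one from compound 2 to compound 3, where one para group was exchanged for another, and that step stayed within the scatter. The step from compound 1 to compound 3, in which a whole aryl group replaced allyl, also stayed within the scatter. Among the compounds with values here, nothing among the measured compounds therefore points to a shift in this assay beyond the scatter for a further para exchange.

Compound 4 is accordingly expected to land near compound 3, with an estimated step of a 1.0-fold higher number from compound 3 to compound 4 (0.01 log units; within the scatter). The estimate for compound 4 in this assay is 1500 nM, with a range from 700 nM to 3200 nM.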

Compound 4, half-maximal inhibitory concentration: 1320 nM
For compound 4 the middle estimate is 1.1-fold (0.06 log units) above the measured one; measured number inside the range.
By their numbers in this assay, from the lowest: compounds 1, 4, 2 and 3 (each within the scatter of the next).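

In this assay the exchange of bromo for methyl on this aromatic carbon, para to a large group, gives a small step (a 1.1-fold lower number from compound 3 to compound 4 (0.05 log units; within the scatter)), and the exchange of nitro for methyl at the same place gives another (a 1.0-fold lower number from compound 2 to compound 4 (0.00 log units; within the scatter)). Going by these compounds alone, this position has now carried bromo, nitro and methyl without any step beyond the scatter, so the one para exchange seen before is no longer alone, and the three aryl compounds cannot be told apart. The 4-methylphenyl group also joins 4-bromophenyl in showing no separation from allyl on the amide-type nitrogen (a 1.1-fold higher number from compound 1 to compound 4 (0.03 log units; within the scatter)), and no evidence at hand bears on why these numbers stay together.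

What the compounds shown leave open is whether any group at this position can move the number beyond the scatter, for instance an amine, a carboxylic acid or a longer chain such as hexyl. With all four compounds within the scatter of one another, they mark no limit to the exchanges this position allows, and they do not show whether the same holds on the amide-type nitrogen for groups other than allyl and these aryl groups.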